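The source may hold more compounds than are shown below. What is called first, only, known or untested is meant among the compounds shown, and "the series" means these compounds.

Measured so far in a physicochemical assay for pharmacokinetics; a lower number here means that the compound disappears faster, a higher number that the compound lasts longer:
Compound 1 `O=C(NCc1ccccc1F)N1C(=O)c2ccccc2S1(=O)=O`: > 166 h
Compound 2 `O=C(NCc1ccc(C(F)(F)F)cc1)N1C(=O)c2ccccc2S1(=O)=O`: > 166 h
Compound 3 `O=C(NCc1ccccc1Cl)N1C(=O)c2ccccc2S1(=O)=O`: > 166 h

None of these three entries is an exact number, since each one is a limit of the assay. In this assay compound 3 gives > 166 h, and this too is only a limit. As far as these compounds go, its true half-life therefore remains unknown, and it cannot be ranked against compound 1 or compound 2.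

Compound 4 `COc1ccccc1CNC(=O)N1C(=O)c2ccccc2S1(=O)=O` has not yet been measured. It carries methoxy in place of chloro on an aromatic carbon, ortho to a large group: methoxy in place of chloro on an aromatic carbon.

Within the data shown here, the one measured step of this kind is a step that the two limits leave unreadable from compound 1 to compound 3, with chloro in place of fluoro on an aromatic carbon. It offers no size to carry over to the new change. The best guide is therefore the shared result, (the limit of > 166 h in this assay, at which 3 of the 3 values shown sit). No step beyond the usual scatter is expected because of the limit of > 166 h in this assay, at which 3 of the 3 values shown sit, and the data point in no direction. The estimated change is a step that the limit leaves unreadable from compound 3 to compound 4. this assay may well return only a limit again.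

The expected half-life of compound 4 is 200 h, with an estimated range from 90 h to 400 h.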

Compound 4, half-life: > 166 h
Compound 4 gave a limit, no number; the forecaster's own chance of this, stated with the estimate: 75%; the middle value is on the limit's open side.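

The steps from compound 3 to compound 4 and from compound 1 to compound 4 cannot be read, because every result is a limit rather than a number: the limit of > 166 h in this assay, at which 4 of the 4 values shown sit.

As far as these compounds go, the true half-lives of compound 1, compound 3 and compound 4 stay open, and so does whether methoxy, chloro or fluoro makes any difference in this assay.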